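This account rests on a few compounds, and the source may have more. Where it says the series, first, only, none or still open, it means among the compounds named here.

Three compounds of this series have numbers in a functional assay on NCI-H23 cells (Homo sapiens) for inhibition, read by sulforhodamine B assay, with a stated time of 48 h; on this read-out higher numbers stand for weaker inhibition of growth and lower numbers for stronger inhibition of growth. Compound 1 `Nc1cc(N)c2nc(-c3ccccc3)c(NCc3ccc(Cl)c(Cl)c3)nc2c1` gives 14100 nM, compound 2 `Nc1cc(N)c2nc(-c3ccccc3)c(Oc3ccc(F)cc3)nc2c1` gives 20900 nM, and compound 3 `Nc1cc(N)c2nc(-c3ccccc3)c(Sc3ccc(Cl)c(Cl)c3)nc2c1` gives 12600 nM. Compound 1 stands second highest of the three, its nearest neighbour being compound 3 and its furthest compound 2, both within the scatter. Among the compounds with values here, the single measured step is a 1.7-fold lower number from compound 2 to compound 3 (0.22 log units; within the scatter). Compound 4 `COc1ccc(CNc2nc3cc(N)cc(N)c3nc2-c2ccccc2)cc1OC` differs from compound 1 by 3,4-dimethoxyphenyl in place of 3,4-dichlorophenyl on a saturated chain carbon bound to a nitrogen on an aromatic ring. Within the data shown here, no measured step touches this part of the molecule, since the step from compound 2 to compound 3 swaps one whole side group for another and so does not bear on it. No step beyond the scatter is therefore expected, and the number for compound 4 in this assay is estimated at 15000 nM, between 5000 nM and 45000 nM, which means an expected step of a 1.1-fold higher number from compound 1 to compound 4 (0.03 log units; within the scatter).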

Compound 4, concentration for 50% growth inhibition: 17000 nM
Compound 4: the middle estimate sits 1.1-fold (0.05 log units) below what was measured, and the stated range covers the measured number.
By their numbers in this assay, from the lowest: compounds 3, 1, 4 and 2 (each within the scatter of the next).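

In this assay, 3,4-dimethoxyphenyl in place of 3,4-dichlorophenyl on a saturated chain carbon bound to a nitrogen on an aromatic ring gives a 1.2-fold higher number from compound 1 to compound 4 (0.08 log units; within the scatter) and so stays within the scatter. Within the data shown here, this is the first step read at this position, and the exchange of the chlorines for methoxy groups, with hydrogen-bond acceptors entering, leaves the two compounds indistinguishable here. No supporting data bear on this result.

Still open, going by these compounds, is whether a carboxylic acid or an amine on this phenyl ring would move the number beyond the scatter. Also open, on these data alone, is what a longer chain carrying the 3,4-dichlorophenyl would do.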